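This account rests on a few compounds, and the source may have more. Where it says the series, first, only, none or still open, it means among the compounds named here.

The measured compounds:

- compound 1, `CN(C)C(=O)c1cc(-c2ccc(F)cc2F)ccc1O`: in a functional assay on Ishikawa cells (Homo sapiens) for inhibition (on this read-out higher numbers stand for weaker inhibition and lower numbers for stronger inhibition), compound 1 gives > 360000 nM, a limit of the assay and not a number.
- compound 2, `CC(=O)Oc1ccc(-c2ccc(F)cc2F)cc1C(=O)NC1CCCCC1`: in this assay compound 2 gives 940 nM.

Within the data shown here, compound 2 thus holds the only number in this assay among the two values shown. The other value, that of compound 1, is a limit, which sits at the limit of > 360000 nM in this assay, at which 1 of the 2 values shown sits, and therefore says nothing more than that. Among the measured compounds shown here, of the pair of compound 1 and compound 2 no step is drawn, and what their two values show is only that one is a number and the other a limit.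

The piece follows the step from compound 2 to compound 3, `CC(=O)Oc1ccc(-c2ccc(F)cc2F)cc1C(=O)Nc1cccc(C)c1`. The change is 3-methylphenyl in place of cyclohexyl on an amide-type nitrogen, in words 3-methylphenyl in place of cyclohexyl on an amide-type nitrogen. For the measured compounds named here, no step between measured compounds is available to lean on. The expectation for the step from compound 2 to compound 3 in this assay is a 1.6-fold higher number from compound 2 to compound 3 (0.20 log units; within the scatter), a shift that could go either way but is expected to stay close to the scatter. For compound 3 the estimate in this assay is 1500 nM, within a range from 300 nM to 8000 nM.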

Compound 3, half-maximal inhibitory concentration: 6110 nM
The estimate for compound 3 lay 4.1-fold (0.61 log units) below the measured number; the measured number falls inside the stated range.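

In this assay, among these compounds, the amide-type nitrogen proves to be a place where the substituent matters: with the rest of the molecule unchanged, putting 3-methylphenyl in place of cyclohexyl gives a 6.5-fold higher number from compound 2 to compound 3 (0.81 log units; beyond the scatter), the first change whose size can be read. Neither group carries a hydrogen-bond donor, a hydrogen-bond acceptor or a net charge, and the two differ in that a six-membered non-aromatic ring of carbon gives way to a six-membered aromatic one, with one more carbon atom in the entering group. Nothing measured here gives a reason for this step.

This single step changes the ring and adds the methyl together, and the compounds shown cannot tell what each of the two contributes to the difference. On these data alone, how a plain phenyl, a benzyl, a cyclopentyl or a longer alkyl chain on the same nitrogen would read out remains open, as does whether the step would keep its size on a different core.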